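A few compounds are considered here, and "the series" means these few. Any claim that something is new, unique, unknown or untested is made for them only; others in the source may bear on it.

- Compound 1 `O=C1CS/C(=N/Nc2nncc3ccccc23)N1c1ccccc1`: 44 nM
- Compound 2 `CCN1C(=O)CS/C1=N/Nc1nncc2ccccc12`: 65 nM
- Compound 3 `Cc1cc(C)nc(NS(=O)(=O)c2ccc(Nc3nncc4ccccc34)cc2)n1`: 3.4 nM

In a functional assay on MDA-MB-435 cells (Homo sapiens) for antiproliferative activity, read by sulforhodamine B assay, with a stated time of 72 h (on this read-out higher numbers stand for weaker inhibition and lower numbers for stronger inhibition), compound 3 gives 3.4 nM, the lowest of the three numbers and beyond the scatter of both others. Compound 4 `O=S(=O)(Nc1ncccn1)c1ccc(Nc2nncc3ccccc23)cc1` carries pyrimidin-2-yl in place of 4,6-dimethylpyrimidin-2-yl on a sulfonamide nitrogen. Among the compounds with values here, the only measured step, a 1.5-fold higher number from compound 1 to compound 2 (0.17 log units; within the scatter), stays within the scatter, but it swaps phenyl for ethyl on an amide-type nitrogen in a ring, so it offers only weak guidance on this change. With compound 3 lowest at 3.4 nM, a modest rise seems likelier than a further fall, and the expected step is a 1.8-fold higher number from compound 3 to compound 4 (0.25 log units; within the scatter). For compound 4 the estimated value is 6 nM, with an expected range of 1.5 nM to 25 nM.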

Compound 4, half-maximal inhibitory concentration: 45 nM
Compound 4: the middle estimate sits 7.5-fold (0.88 log units) below what was measured, outside the stated range (above it).
By their numbers in this assay, from the lowest: compound 3; then compounds 1, 4 and 2 (each within the scatter of the next).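

In this assay, pyrimidin-2-yl in place of 4,6-dimethylpyrimidin-2-yl on a sulfonamide nitrogen gives a 13-fold higher number from compound 3 to compound 4 (1.12 log units; beyond the scatter), the only step shown that lies beyond the scatter. This sulfonamide substituent therefore matters to the read-out, even though the ring type and the counted hydrogen-bond donors and acceptors stay the same. Nothing available explains the size of this step.

From the compounds shown here alone, it remains open whether a single methyl on the pyrimidine would suffice, and whether ethyl, methoxy or an amine there would match compound 3. Going by these compounds, how a phenyl or pyridin-2-yl group on the same nitrogen would compare also remains open.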